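Swapping Piperidinyl for Difluorophenyl: Expected Vero Cell Tolerance

The source may hold more compounds than are shown below. What is called first, only, known or untested is meant among the compounds shown, and "the series" means these compounds.

Measured so far:
compound 1 `C[C@]1(CN2CCc3nc(-c4ccc(F)cc4)sc3C2)Cn2cc([N+](=O)[O-])nc2O1`: > 32 ug/mL
compound 2 `C[C@]1(CN2CCc3nc(N4CCCCC4)ccc3C2)Cn2cc([N+](=O)[O-])nc2O1`: "not determined" (no result reported)

In an ADME assay on Vero cells (Chlorocebus sabaeus) for cytotoxicity, read by MTT assay, with a stated time of 72 h (a lower number here means that less compound is tolerated, a higher number that more compound is tolerated), compound 1 reaches only a limit, > 32 ug/mL, and no number. Going by the values given here, for compound 2 the result in this assay reads "not determined" (no result reported), so compound 2 has no number of its own to stand on; the only value shown anywhere is the limit of > 32 ug/mL in this assay, at which 1 of the 2 values shown sits. Compound 3 `C[C@]1(CN2CCc3nc(-c4cc(F)cc(F)c4)ccc3C2)Cn2cc([N+](=O)[O-])nc2O1` differs from compound 2 in one place: 3,5-difluorophenyl in place of piperidin-1-yl on an aromatic carbon. Among the compounds with values here, no measured step exists for this change, so nothing fixes its size. With one value shown, and that a limit, no direction can be drawn for compound 3 in this assay; the step is expected to lie within the scatter or to end at the limit once more. Compound 3 is therefore expected to give 32 ug/mL, with a range from 12 ug/mL to 64 ug/mL.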

Compound 3, half-maximal cytotoxic concentration: > 32 ug/mL
Compound 3: a limit, no number; the forecaster's own chance of this, stated with the estimate: 70%; the middle value sits exactly at the limit.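

In this assay compound 3 gives > 32 ug/mL, which is a limit and not a number. No step can be read between compound 2 and compound 3, since neither has a number. The compounds shown leave open how much of each is tolerated in this assay, and whether 3,5-difluorophenyl in place of piperidin-1-yl changes that at all.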